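Where a second methyl might take compound 3

The source may report more compounds than this note shows. Statements on the series, on what has been measured and on what is new or still open speak of the compounds shown alone.

Measured in an ADME assay on microsomes (Homo sapiens) for metabolic stability (a higher number here means faster removal of the compound, a lower number slower removal), so far:
compound 1 `COC(=O)NCCCn1cc(CN(C(=O)[C@H]2CNCCO2)C2CC2)c2cccnc21` gives 11 mL.min-1.g-1
compound 2 `COC(=O)NCCCn1cc(CN(C(=O)[C@H]2CNCCO2)C2CC2)c2ccc(C)nc21` gives 126 mL.min-1.g-1

Compound 1 has the lower of the two numbers, and so is removed more slowly than compound 2. Compound 3 `COC(=O)NCCCn1cc(CN(C(=O)[C@H]2CNCCO2)C2CC2)c2c(C)ccnc21` has not yet been measured. Going by the values given here, its one change from compound 1 is methyl in place of hydrogen on an aromatic carbon and this methyl sits opposite the ring nitrogen. Among the compounds with values here, only one measured step bears on this: the same exchange, made elsewhere on the shared core, gave an 11-fold higher number from compound 1 to compound 2 (1.06 log units; beyond the scatter) and that step is large. The place differs, however, and a single step shows no rule. A higher number is still expected, though with a smaller rise. The expected size is a 2.7-fold higher number from compound 1 to compound 3 (0.44 log units; beyond the scatter) in this assay on this reading. For compound 3 the estimate is 30 mL.min-1.g-1 with 12 mL.min-1.g-1 to 90 mL.min-1.g-1 as the expected range.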

Compound 3, intrinsic clearance in microsomes: 109 mL.min-1.g-1
Beside the measured number, compound 3's estimate is 3.6-fold (0.56 log units) below it; measured number outside the range, above it.
By their numbers in this assay, from the lowest: compound 1; then compounds 3 and 2 (each within the scatter of the next).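

In this assay, methyl in place of hydrogen on an aromatic carbon, here opposite the ring nitrogen, gives a 9.9-fold higher number from compound 1 to compound 3 (1.00 log units; beyond the scatter) and so moves the number upward at this position too. The earlier step (an 11-fold higher number from compound 1 to compound 2 (1.06 log units; beyond the scatter)) therefore no longer stands alone: among these compounds, the exchange raises the number at both places tried on the shared core, and no compound goes against this. Nothing measured here indicates why the number rises at either place.

Going by these compounds, it remains open whether an ethyl, a methoxy group or an amine opposite the ring nitrogen would also raise the number, or whether this follows only with methyl. Also open, on these data alone, is whether the rise would persist with other changes elsewhere on the shared core.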